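From compound 3 to compound 4: a side-chain exchange

The source may report more compounds than this note shows. Statements on the series, on what has been measured and on what is new or still open speak of the compounds shown alone.

In a functional assay on the whole organism for inhibition, with Mus musculus as the target (a higher number here means that more compound is needed for the effect, a lower number that less compound is needed), compound 3 (`CC(C)NCCC(=O)Nc1cccc2c1CN(C)CC2c1ccccc1`) gives 150 mg/kg, the higher of the two numbers in the series. Compound 2 (`CCCCOC(=O)Nc1cccc2c1CN(C)CC2c1ccccc1`) gives 4 mg/kg, the nearest value. Compound 1 (`CCCNC(=O)Nc1cccc2c1CN(C)CC2c1ccccc1`) gives > 80 mg/kg, which is a limit of the assay and not a number.

The next structure is compound 4 (`CN1Cc2c(NC(=O)CN3CCCCC3)cccc2C(c2ccccc2)C1`). The change is piperidin-1-yl in place of (isopropylamino)methyl on a saturated chain carbon bound to a carbonyl carbon, which can also be read as 2-(isopropylamino)ethyl to (piperidin-1-yl)methyl.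

Among the compounds with values here, no measured step makes this exchange. The nearest evidence is two large steps on the same carbonyl carbon, an at least 20-fold lower number from compound 1 to compound 2 (1.30 log units; beyond the scatter) and a 38-fold higher number from compound 2 to compound 3 (1.57 log units; beyond the scatter). Both involve butoxy, which is absent from compound 3 and compound 4. The remaining step, a step that the limit leaves unreadable from compound 1 to compound 3, rests on (the limit of > 80 mg/kg in this assay, at which 1 of the 3 values shown sits). Within the data shown here, no large step is therefore expected, only a slight drift towards a lower number, and the expected step is a 1.7-fold lower number from compound 3 to compound 4 (0.22 log units; within the scatter). For compound 4 the estimate is 90 mg/kg, with an expected range of 25 mg/kg to 280 mg/kg.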

Compound 4, dose for half-maximal effect: about 65 mg/kg
Beside the measured number, compound 4's estimate is 1.4-fold (0.14 log units) above it, and the stated range covers the measured number.
By their numbers in this assay, from the lowest: compound 2; then compound 4; then compound 3.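

On the saturated chain carbon bound to a carbonyl carbon, piperidin-1-yl is tolerated in this assay, with a 2.3-fold lower number from compound 3 to compound 4 (0.36 log units; beyond the scatter). Butoxy on the carbonyl carbon keeps a far lower number, with a 16-fold higher number from compound 2 to compound 4 (1.21 log units; beyond the scatter), so the amine exchange on this chain moves the number much less than replacing butoxy with either amine-bearing chain. The comparison with compound 1 gives only a floor, an at least 1.2-fold lower number from compound 1 to compound 4 (0.09 log units; that floor lies within the scatter), and the value of compound 1 is a limit of the assay: the limit of > 80 mg/kg in this assay, at which 1 of the 4 values shown sits.

The reading of 2-(isopropylamino)ethyl to (piperidin-1-yl)methyl combines the ring with a change of chain, and these two changes stay unseparated. On these data alone, whether morpholin-4-yl or dimethylamino on the same chain carbon, or a longer alkoxy chain on the carbonyl carbon, would reach or pass the number of compound 2 remains open.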